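The source may report more compounds than this note shows. Statements on the series, on what has been measured and on what is new or still open speak of the compounds shown alone.

Measured so far:
compound 1 `CCCCOc1ccc(/N=c2\ssnc2Cl)cc1` — > 100000 nM
compound 2 `O=S(=O)(Nc1nccs1)c1ccc(/N=c2\ssnc2Cl)cc1` — 97000 nM

In a functional assay on PANC-1 cells (Homo sapiens) for cytotoxicity, read by resazurin assay, with a stated time of 72 h (on this read-out lower numbers stand for stronger inhibition and higher numbers for weaker inhibition), compound 1 reaches only > 100000 nM, which is a limit of the assay and not a number. Among the measured compounds shown here, compound 2 gives 97000 nM in this assay, the single real number among the values shown, the other sitting at the limit of > 100000 nM in this assay, at which 1 of the 2 values shown sits. Compound 3 `O=S(=O)(Nc1ncccn1)c1ccc(/N=c2\ssnc2Cl)cc1` carries pyrimidin-2-yl in place of 1,3-thiazol-2-yl on a sulfonamide nitrogen. For the measured compounds named here, no measured pair covers this change, so its size is open. The expectation is no shift beyond the scatter, a 1.0-fold higher number from compound 2 to compound 3 (0.01 log units; within the scatter). Compound 3 is therefore estimated at 100000 nM, between 40000 nM and 250000 nM, with a fair chance that only a limit is reported.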

Compound 3, half-maximal inhibitory concentration: 37000 nM
For compound 3 the middle estimate is 2.7-fold (0.43 log units) above the measured one, outside the stated range (below it).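

In this assay, among the compounds shown here, pyrimidin-2-yl in place of 1,3-thiazol-2-yl on a sulfonamide nitrogen gives a 2.6-fold lower number from compound 2 to compound 3 (0.42 log units; beyond the scatter), the first readable step. The ring held at this position therefore moves the read-out, though only modestly, and this rests on a single pair. Nothing shown gives a cause for this step.

From the compounds shown here alone, whether a methyl, a morpholine or a carboxylic acid on that sulfonamide nitrogen would shift the number further remains open. So does whether a larger step is available here at all.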